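A fluoro group added to compound 2

The compounds below may be only part of what the source reports. "The series", "measured", "known", "first", "only" and "open" are said of these compounds alone.

Of the compounds shown here, two have been measured so far. In a functional assay on the whole organism with Mus musculus as the target, in the rotarod test (a higher number here means that more compound is needed for the effect, a lower number that less compound is needed), compound 1 (`NC(=O)/C=C1/CCc2ccc(F)cc21`) gives 92 mg/kg and compound 2 (`NC(=O)/C=C1\CCc2ccccc21`) gives 164 mg/kg as its reading. These two values lie within the usual scatter of each other, so compound 2 stands level with compound 1 on the numbers available.

Compound 3 (`NC(=O)/C=C1\CCc2ccc(F)cc21`) has fluoro in place of hydrogen on an aromatic carbon of compound 2 (fluoro in place of hydrogen on an aromatic carbon) and awaits measurement. For the measured compounds named here, no measured pair shows this change on its own, so the data give no direct size for it. Going by the values given here, compound 1, which also carries fluoro, reads 92 mg/kg in this assay and offers the only guide. A small move toward lower numbers is expected, not beyond the scatter. The expected step is a 1.4-fold lower number from compound 2 to compound 3 (0.14 log units; within the scatter) in size. The estimate for compound 3 is 120 mg/kg with an expected range from 60 mg/kg to 240 mg/kg once measured.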

Compound 3, dose for half-maximal effect: 90 mg/kg
For compound 3 the middle estimate is 1.3-fold (0.12 log units) above the measured one; the measured number falls inside the stated range.
By their numbers in this assay, from the lowest: compounds 3, 1 and 2 (each within the scatter of the next).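

In this assay, this pair gives fluoro in place of hydrogen on an aromatic carbon its only measured size, a 1.8-fold lower number from compound 2 to compound 3 (0.26 log units; within the scatter), so at this position the change does not stand clear of the scatter. Changing only how the double bond is drawn, Z against E, gives a 1.0-fold lower number from compound 1 to compound 3 (0.01 log units; within the scatter), and this configuration therefore does not separate the two fluoro compounds in this assay either. That second comparison isolates a single structural difference: the fact that compounds 1 and 3 differ only in the configuration as drawn

From the compounds shown here alone, whether chloro, methoxy or an amine on this same aromatic carbon would give a step beyond the scatter remains open. So does the effect of fluoro on another aromatic carbon of the six-membered ring, or of a carboxylic acid in place of the amide.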